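The source may report more compounds than this note shows. Statements on the series, on what has been measured and on what is new or still open speak of the compounds shown alone.

Among the measured compounds shown here, compound 2 `O=C(CSc1nnc(NC(=O)CCl)s1)Nc1ccc(Br)cn1` is the only compound of the pair that gives a number: in a functional assay on NCI-H460 cells (Homo sapiens) for antiproliferative activity, read by MTT assay, with a stated time of 48 h (on this read-out higher numbers stand for weaker inhibition and lower numbers for stronger inhibition), compound 2 gives 7500 nM. In this assay compound 1 `COc1ccccc1C(=O)Nc1nnc(SCC(=O)Nc2ccc(Br)cn2)s1` gives only a limit of the measurement, > 80000 nM. Compound 3 `O=C(CSc1nnc(NC(=O)C(Cl)Cl)s1)Nc1ccc(Br)cn1` differs from compound 2 by chloro in place of hydrogen on a saturated chain carbon bound to a carbonyl carbon and a chlorine atom. For the measured compounds named here, the only measured step, an at least 10-fold lower number from compound 1 to compound 2 (1.02 log units; beyond the scatter), concerns a different change at the same carbonyl and so offers little guidance here. No step beyond the scatter is expected, and the step of a 1.3-fold lower number from compound 2 to compound 3 (0.10 log units; within the scatter) is estimated to be small. Compound 3 is therefore expected to give about 6000 nM in this assay, with a range from 2000 nM to 20000 nM.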

Compound 3, half-maximal inhibitory concentration: 5300 nM
Compound 3: middle estimate off by 1.1-fold (0.05 log units), on the high side; the measured number falls inside the stated range.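

In this assay, turning chloromethyl into dichloromethyl gives a 1.4-fold lower number from compound 2 to compound 3 (0.15 log units; within the scatter), so a second chlorine on this carbon leaves compound 2 and compound 3 indistinguishable. Dichloromethyl in place of 2-methoxyphenyl on the carbonyl carbon gives an at least 15-fold lower number from compound 1 to compound 3 (1.17 log units; beyond the scatter), so a second chlorinated group at this carbonyl stands well apart from the 2-methoxyphenyl compound. The size of that step stays open-ended because compound 1 gives only a limit: the limit of > 80000 nM in this assay, at which 1 of the 3 values shown sits.

From the compounds shown here alone, it remains open whether trichloromethyl would fit this series. A plain methyl or a chlorine-free aminomethyl group at this carbonyl would show whether chlorine is needed at all.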